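From compound 2 to compound 3: a change on the amide nitrogen

The source may hold more compounds than are shown below. What is called first, only, known or untested is meant among the compounds shown, and "the series" means these compounds.

In a physicochemical assay for pharmacokinetics, at pH 4 (a higher number here means that the compound lasts longer, a lower number that the compound disappears faster), compound 1 (`Cc1ccc(Oc2ccc(C(=O)NCC3CCCCC3)cc2)cc1`) gives > 1000 h as a limit and not a number. Compound 2 (`Cc1ccc(Oc2ccc(C(=O)N(C)Cc3ccncc3)cc2)cc1`) gives > 1000 h as well, again a limit, so it stands without a number of its own. For the measured compounds named here, the series so far consists of the limit of > 1000 h in this assay, at which 2 of the 2 values shown sit, and holds no measured step.

Compound 3 (`CNC(=O)c1ccc(Oc2ccc(C)cc2)cc1`) carries hydrogen in place of (pyridin-4-yl)methyl on an amide-type nitrogen. What such a change does in this assay is shown by no measured step. The expectation rests on compound 2 with its limit of > 1000 h as the only starting point. The expected change is a step that the limit leaves unreadable from compound 2 to compound 3 in this estimate, with no shift in either direction beyond the scatter. The expected half-life of compound 3 is 1200 h (estimated range 700 h to 2500 h), and a report as a limit is likely.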

Compound 3, half-life: > 1000 h
Compound 3 gave a limit, no number; the forecaster's own chance of this, stated with the estimate: 90%; the middle value does not contradict the limit.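

In this assay compound 3 gives > 1000 h, a limit and not a number, so its steps from compound 1 and compound 2 cannot be read. The compounds shown leave open what actual half-lives lie behind these limits and whether any change on the amide nitrogen would shorten them.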